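Cytotoxicity notes on a benzoxazinone enaminone series

A few compounds are considered here, and "the series" means these few. Any claim that something is new, unique, unknown or untested is made for them only; others in the source may bear on it.

Working notes on three analogues sharing one core, followed in an ADME assay on Vero cells (Chlorocebus sabaeus) for cytotoxicity, read by MTT assay, with a stated time of 72 h; on this read-out lower numbers stand for higher toxicity in this test and higher numbers for lower toxicity in this test. Compound 1 `Cc1ccccc1C(=O)/C=C1\Nc2ccccc2OC1=O` is measured only as a limit in this assay, giving > 1790000 nM. Compound 2 `O=C1Oc2ccccc2N/C1=C\C(=O)c1ccc(-c2ccccc2)cc1` likewise returns a limit in this assay, > 366000 nM. Among the measured compounds shown here, compound 1 therefore stands at a limit and not at a number, as does the only other value shown; no step between measured compounds has been resolved, and the two limits differ only in where the assay stopped (the limit of > 1790000 nM in this assay, at which 1 of the 2 values shown sits, (the limit of > 366000 nM in this assay, at which 1 of the 2 values shown sits)).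

Compound 3 `O=C1Oc2ccccc2N/C1=C\C(=O)c1ccncc1` is not yet measured in this assay. It differs from compound 1 by pyridin-4-yl in place of 2-methylphenyl on a carbonyl carbon.

With both measured compounds sitting at limits in this assay, the expectation for compound 3 is no step beyond the scatter, and most likely a limit again. Compound 3 is expected to give 1500000 nM in this assay, within 300000 nM to 5000000 nM. The expected step of an at least 1.1-fold lower number from compound 1 to compound 3 (0.07 log units; that floor lies within the scatter) is thus essentially none.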

Compound 3, half-maximal cytotoxic concentration: > 1870000 nM
Compound 3 gave a limit, no number (the forecaster's own chance of this, stated with the estimate: 85%); middle value at least 1.2-fold (0.09 log units) from the limit.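

No step can be read between compound 1 and compound 3 in this assay: both return limits, not numbers. The compounds shown leave open whether pyridin-4-yl in place of 2-methylphenyl on a carbonyl carbon changes the half-maximal cytotoxic concentration at all.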